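Chloro for hydrogen on the benzyl ring of compound 3

A few compounds are considered here, and "the series" means these few. Any claim that something is new, unique, unknown or untested is made for them only; others in the source may bear on it.

Measured in a functional assay on MNK45 cells (Homo sapiens) for inhibition, read by MTT assay, with a stated time of 48 h; on this read-out lower numbers stand for stronger inhibition and higher numbers for weaker inhibition: compound 1 `Cc1ccc(NC(=S)NC(=O)c2ccc(OCc3ccccc3F)cc2)cc1-c1nc2ccccc2[nH]1` gives 2420 nM; compound 2 `Cc1ccc(NC(=S)NC(=O)c2ccc(OCc3ccc(Cl)cc3Cl)cc2)cc1-c1nc2ccccc2[nH]1` gives 5300 nM; compound 3 `Cc1ccc(NC(=O)NC(=O)c2ccc(OCc3ccccc3)cc2)cc1-c1nc2ccccc2[nH]1` gives 35100 nM.

Compound 3 therefore stands at the highest number of the three, with compound 2 nearest and compound 1 furthest from it. Compound 4 `Cc1ccc(NC(=O)NC(=O)c2ccc(OCc3ccccc3Cl)cc2)cc1-c1nc2ccccc2[nH]1` differs from compound 3 by chloro in place of hydrogen on an aromatic carbon. Among the measured compounds shown here, only one step is on record, a 2.2-fold higher number from compound 1 to compound 2 (0.34 log units; beyond the scatter), and it swaps one substituted benzyl ring for another within the pair of compounds 1 and 2; it does not start from a plain benzyl, so no measured step covers this change directly. The step is therefore expected to be no larger than the scatter, a 1.4-fold lower number from compound 3 to compound 4 (0.13 log units; within the scatter). For compound 4 the estimate is 26000 nM, within the range 8000 nM to 80000 nM.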

Compound 4, half-maximal inhibitory concentration: 21500 nM
The estimate for compound 4 lay 1.2-fold (0.08 log units) above the measured number; low and high end bracket the measured number.
By their numbers in this assay, from the lowest: compound 1; then compound 2; then compounds 4 and 3 (each within the scatter of the next).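

On the benzyl ring, chloro in place of hydrogen, ortho to a large group, gives a 1.6-fold lower number from compound 3 to compound 4 (0.21 log units; within the scatter) in this assay, so benzyl and 2-chlorobenzyl are not told apart here. The earlier step compared two substituted rings, whereas this one starts from the plain benzyl and shows that this single chloro does not shift the number beyond the scatter. Nothing available gives a reason for this result.

From the compounds shown here alone, whether an amine or a carboxylic acid at this position would give a step beyond the scatter remains open. So does whether chloro would behave alike on the linker of compound 1.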